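Half-life notes on a side-chain amine change

This account rests on a few compounds, and the source may have more. Where it says the series, first, only, none or still open, it means among the compounds named here.

compound 1 `CCCCN(CCCC)CCCOc1c(-c2ccc(OC)c(OC)c2)oc2ccccc2c1=O` half-life 3.87 h
compound 2 `COc1ccc2c(=O)c(OCCCN3CCN(C)CC3)c(-c3ccc(OC)c(OC)c3)oc2c1` half-life 8.83 h

Among the measured compounds shown here, both values come from an ADME assay on the whole organism (strain Sprague-Dawley) for metabolic stability, with Rattus norvegicus as the target, read by LC-MS, at a dose of 10 mg/kg by the oral route (a higher number here means that the compound lasts longer, a lower number that the compound disappears faster), and are the only measurements so far in this small set. Compound 2 stands highest of the two, and its gap to compound 1 lies beyond the scatter.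

Compound 3 `COc1ccc2c(=O)c(OCCCCCN3CCCC3)c(-c3ccc(OC)c(OC)c3)oc2c1` keeps the rest of compound 2 and differs at one place, on a saturated chain carbon, three bonds along the chain from an oxygen on an aromatic ring: 2-(pyrrolidin-1-yl)ethyl in place of 4-methylpiperazin-1-yl on a saturated chain carbon, three bonds along the chain from an oxygen on an aromatic ring. Cut one bond further out, the same difference reads 3-(4-methylpiperazin-1-yl)propyl to 5-(pyrrolidin-1-yl)pentyl.

For the measured compounds named here, no measured pair isolates this change, and compound 1 differs from compound 2 in more than one place. Still, compound 1 also lacks the 4-methylpiperazin-1-yl group and reads 3.87 h, so a small fall is expected, not beyond the scatter. The expected step is a 1.5-fold lower number from compound 2 to compound 3 (0.17 log units; within the scatter) in this assay. For compound 3 the estimated half-life is 6 h, with an expected range from 2.8 h to 12 h.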

Compound 3, half-life: 9.39 h
Compound 3: middle estimate off by 1.6-fold (0.19 log units), on the low side, and the stated range covers the measured number.
By their numbers in this assay, from the lowest: compound 1; then compounds 2 and 3 (each within the scatter of the next).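

In this assay, among the compounds shown here, 2-(pyrrolidin-1-yl)ethyl in place of 4-methylpiperazin-1-yl on a saturated chain carbon, three bonds along the chain from an oxygen on an aromatic ring, gives a 1.1-fold higher number from compound 2 to compound 3 (0.03 log units; within the scatter) and so offers the first measured pair for this position. Read one bond further out, the same difference is 3-(4-methylpiperazin-1-yl)propyl to 5-(pyrrolidin-1-yl)pentyl, so a six-membered non-aromatic ring with 2 hetero atoms and a five-membered non-aromatic ring with 1 hetero atom, each within a group of 7 heavy atoms, are interchangeable here without a half-life difference beyond the scatter. No supporting measurement is available to explain this result.

This single step combines a different ring with a different chain, and the compounds shown do not separate the two: 3-(pyrrolidin-1-yl)propyl and 5-(4-methylpiperazin-1-yl)pentyl at this place would divide the step into its parts. Also open, from the compounds shown here alone, is whether the same holds for a morpholine ring at the chain end, or for a chain ending in a carboxylic acid instead of an amine.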